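The source may hold more compounds than are shown below. What is called first, only, known or untested is meant among the compounds shown, and "the series" means these compounds.

Measured compounds:
- compound 1, `O=C(/C(=C\c1ccc(Br)c(O)c1)S(=O)(=O)c1ccc(Br)cc1)c1ccc(Br)cc1`: in a functional assay on DU-145 cells (Homo sapiens) for inhibition, read by trypan blue exclusion, with a stated time of 96 h (a higher number here means a weaker inhibitor of growth, a lower number a stronger inhibitor of growth), compound 1 gives 50000 nM
- compound 2, `Cc1ccc(CS(=O)(=O)/C(=C/c2c(O)cc(O)cc2O)C(=O)c2ccc(Cl)cc2)cc1`: in this assay compound 2 gives > 100000 nM, which is a limit of the assay and not a number
- compound 3, `O=C(/C(=C\c1ccc(Oc2ccccc2)cc1)SCc1ccccc1Cl)c1ccc(Cl)cc1`: in this assay compound 3 gives 1000 nM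

Among the two numbers given, compound 1 holds the highest; the nearest number, that of compound 3, is far lower, a gap well beyond the scatter. Going by the values given here, compound 2 sits at the limit of > 100000 nM in this assay, at which 1 of the 3 values shown sits, and so shows only that its value lies past the reach of the assay.

Compound 4, `O=C(/C(=C\c1ccc(F)c([N+](=O)[O-])c1)S(=O)(=O)c1ccc(Br)cc1)c1ccc(Br)cc1`, is not yet measured. It differs from compound 1 in one place: 4-fluoro-3-nitrophenyl in place of 4-bromo-3-hydroxyphenyl on a double-bonded chain carbon bound to a double-bonded chain carbon. The rest of compound 1 is kept unchanged. Among the compounds with values here, no pair of measured compounds differing in one place exists in this set, so no measured step can guide the size of this one. Within the data shown here, the expectation is a step of no more than the scatter, in either direction, as the only anchor is compound 1 at 50000 nM. Compound 4 is therefore estimated at 40000 nM, with a range from 12000 nM to 100000 nM, meaning an expected step of a 1.3-fold lower number from compound 1 to compound 4 (0.10 log units; within the scatter). Given that one of the three values already sits at the limit, a limit-only result for compound 4 would not surprise.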

Compound 4, concentration for 50% growth inhibition: 25000 nM
Compound 4: middle estimate off by 1.6-fold (0.20 log units), on the high side; the range from low to high includes it.
By their numbers in this assay, from the lowest: compound 3; then compounds 4 and 1 (each within the scatter of the next). At a limit, above all of these: compound 2.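

In this assay, going by these compounds alone, 4-fluoro-3-nitrophenyl in place of 4-bromo-3-hydroxyphenyl on a double-bonded chain carbon bound to a double-bonded chain carbon gives a 2.0-fold lower number from compound 1 to compound 4 (0.30 log units; within the scatter) and provides the first one-place comparison. In this single pair, the hydroxyl and bromine of compound 1 are replaced by nitro and fluorine without a step beyond the scatter, so neither original substituent is shown to be required at this position. Nothing measured here bears on a cause for this step.

As far as these compounds go, whether an amine or a carboxylic acid at this position would give a step beyond the scatter remains open, as does whether the same exchange behaves alike on another core. Compound 2 remains a limit of the assay and not a number: the limit of > 100000 nM in this assay, at which 1 of the 4 values shown sits.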